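The compounds below may be only part of what the source reports. "The series", "measured", "known", "first", "only" and "open" are said of these compounds alone.

Measured in a functional assay on M14 cells (Homo sapiens) for inhibition, read by sulforhodamine B assay, with a stated time of 48 h, tested at 100 uM; on this read-out higher numbers stand for a weaker effect at the one concentration tested and lower numbers for a stronger effect:
compound 1, `COc1cc(Cl)cc(-c2nn(-c3cccc(NC(=O)Nc4ccc(Cl)c(C(F)(F)F)c4)c3)cc2-c2ccncc2)c1`, gives -70%.
compound 2, `COc1cc(Cl)cc(-c2nn(-c3cccc(NC(=O)Nc4cccc(C(F)(F)F)c4)c3)cc2-c2ccncc2)c1`, gives -78%.

Compound 2 gives the lower of the two numbers shown, but its gap to compound 1 is within the scatter, so the two are not distinguished; the single measured step, a number 8 percentage points lower from compound 1 to compound 2 (within the scatter), is within the scatter. Compound 3, `COc1cc(Cl)cc(-c2nn(-c3cccc(NC(=O)c4cccc(C(F)(F)F)c4)c3)cc2-c2ccncc2)c1`, carries 3-(trifluoromethyl)phenyl in place of (3-(trifluoromethyl)phenyl)amino on a carbonyl carbon. For the measured compounds named here, no measured step touches the carbonyl linker, so the step from compound 1 to compound 2 offers no direct guide; the expectation in this assay is a step within the scatter, leaning weaker. Compound 3 is estimated at -65% (range -95% to -20%), the expected step being a number 13 percentage points higher from compound 2 to compound 3 (beyond the scatter).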

Compound 3, a percentage reported as activity, at one concentration (the size of the read-out at that concentration, not a potency): 27%
Estimate against measurement, compound 3: 92 percentage points below; the measured number lies above the stated range.
By their numbers in this assay, from the lowest: compounds 2 and 1 (each within the scatter of the next); then compound 3.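

The carbonyl carbon proves a far more sensitive place than the chloro site: in this assay, 3-(trifluoromethyl)phenyl in place of (3-(trifluoromethyl)phenyl)amino gives a number 105 percentage points higher from compound 2 to compound 3 (beyond the scatter). With the chloro group also gone, the change gives a number 97 percentage points higher from compound 1 to compound 3 (beyond the scatter); both steps mark a much weaker effect, and both remove the amino nitrogen with its hydrogen-bond donor. Nothing at hand explains the size of these steps.

As far as these compounds go, whether the nitrogen, its hydrogen or the length of the link matters remains open. A methylene or an oxygen in place of that amino nitrogen would separate these.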